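A few compounds are considered here, and "the series" means these few. Any claim that something is new, unique, unknown or untested is made for them only; others in the source may bear on it.

Three compounds have already been measured in a functional assay on SF-539 cells (Homo sapiens) for inhibition, read by sulforhodamine B assay, with a stated time of 48 h; a lower number here means a stronger inhibitor of growth, a higher number a weaker inhibitor of growth:
compound 1, `O=C(Nc1cccc(-n2cc(-c3ccncc3)c(-c3ccc(Cl)c(O)c3)n2)c1)Nc1ccc(Cl)c(Cl)c1`, gives 8970 nM;
compound 2, `COc1cc(-c2nn(-c3cccc(NC(=O)c4cccc(C(F)(F)F)c4)c3)cc2-c2ccncc2)ccc1Cl`, gives 2300 nM;
compound 3, `COc1cc(-c2nn(-c3cccc(NC(=O)Nc4cccc(C(F)(F)F)c4)c3)cc2-c2ccncc2)ccc1Cl`, gives 2420 nM.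

Compound 1 carries the highest number of the three; compound 3 sits nearest to it and compound 2 furthest, both gaps lying beyond the scatter. The only single-point step among these, a 1.1-fold higher number from compound 2 to compound 3 (0.02 log units; within the scatter), concerns (3-(trifluoromethyl)phenyl)amino in place of 3-(trifluoromethyl)phenyl on a carbonyl carbon and is within the scatter, so it does not bear on the change now in view. Among the measured compounds shown here, compound 4, `O=C(Nc1cccc(-n2cc(-c3ccncc3)c(-c3ccc(Cl)c(O)c3)n2)c1)Nc1ccc(Cl)c(C(F)(F)F)c1`, differs from compound 1 by trifluoromethyl in place of chloro on an aromatic carbon; no measured pair shows this exchange of chloro for trifluoromethyl, so the expectation rests on compound 1 alone. The expected step of a 1.4-fold lower number from compound 1 to compound 4 (0.14 log units; within the scatter) is therefore small, within or barely beyond the scatter, in either direction. Compound 4 is estimated at 6500 nM, with a range from 2000 nM to 20000 nM.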

Compound 4, concentration for total growth inhibition: 2390 nM
For compound 4 the middle estimate is 2.7-fold (0.43 log units) above the measured one, and the stated range covers the measured number.
By their numbers in this assay, from the lowest: compounds 2, 4 and 3 (each within the scatter of the next); then compound 1.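

In this assay, the change from 3,4-dichlorophenyl to 4-chloro-3-(trifluoromethyl)phenyl gives a 3.8-fold lower number from compound 1 to compound 4 (0.57 log units; beyond the scatter). This is the first step among these compounds that lies beyond the scatter and the first to show that the number responds to the group on this aromatic carbon, ortho to a chloro group. No measurement given here accounts for the step.

The compounds shown leave open how a nitrile or a methyl group on this carbon would compare with trifluoromethyl. Going by these compounds, it also remains open whether the same exchange would give a similar step in compounds carrying methoxy instead of the hydroxy group of compound 1.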